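A few compounds are considered here, and "the series" means these few. Any claim that something is new, unique, unknown or untested is made for them only; others in the source may bear on it.

Measured compounds:
- compound 1, `COc1ccc2occ(CSC(=S)N(C(C)C)C(C)C)c(=O)c2c1`: > 40000 nM
- compound 2, `O=c1c(CSC(=S)N2CCOCC2)coc2cc(Cl)ccc12`: 8100 nM

Compound 1 was tested in a functional assay on MCF7 cells (Homo sapiens) for antiproliferative activity, read by MTT assay, with a stated time of 72 h; on this read-out lower numbers stand for stronger inhibition and higher numbers for weaker inhibition. Its result, > 40000 nM, is a limit of the assay rather than a number, so its true place is not known. Compound 2 gives 8100 nM in this assay. Going by the values given here, the only value that fixes a position on the scale is the one for compound 2; compound 1 sits at the limit, a fact recorded as the limit of > 40000 nM in this assay, at which 1 of the 2 values shown sits.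

Compound 3, `COc1ccc2occ(CSC(=S)N3CCOCC3)c(=O)c2c1`, is not yet measured. It differs from compound 1 in one place: morpholin-4-yl in place of diisopropylamino on a thiocarbonyl carbon, or in words, morpholin-4-yl in place of diisopropylamino on a thiocarbonyl carbon. Among the compounds with values here, no step between two measured compounds shows what this change does. Compound 2 also carries a morpholin-4-yl group and does return a number, so a move toward stronger inhibition in this assay is expected rather than none.

For compound 3 the expected step of an at least 2.6-fold lower number from compound 1 to compound 3 (0.42 log units; beyond the scatter) points toward stronger inhibition. Compound 3 is estimated at 15000 nM, with a range from 5000 nM to 40000 nM.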

Compound 3, half-maximal inhibitory concentration: 11800 nM
Beside the measured number, compound 3's estimate is 1.3-fold (0.10 log units) above it; the range from low to high includes it.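

With the core held the same, morpholin-4-yl in place of diisopropylamino on a thiocarbonyl carbon gives an at least 3.3-fold lower number from compound 1 to compound 3 (0.53 log units; beyond the scatter) in this assay. Going by these compounds alone, this is the first reading of this change on its own, and it shows that the group at this place has a real bearing on the read-out, which compound 2 could only suggest with its other differences from compound 1. The size of the step is only a minimum, because compound 1 stands at a limit and not at a number: the limit of > 40000 nM in this assay, at which 1 of the 3 values shown sits.

Going by these compounds, what remains open is whether the ring of morpholin-4-yl or its oxygen matters more. A piperidin-1-yl group, with carbon where that oxygen stands, would separate the two, and a dimethylamino group would show how an open-chain amine behaves at this place.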